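Shortening one side chain: its effect on cell inhibition

This account rests on a few compounds, and the source may have more. Where it says the series, first, only, none or still open, it means among the compounds named here.

Measured compounds:
compound 1 `CC(C)=CCC/C(C)=C/C[C@]12C(=O)CC(=O)[C@](CC=C(C)C)(C[C@@H](CC=C(C)C)C1(C)C)C2=O`: 8.5 ug/mL
compound 2 `CC(C)=CCC/C(C)=C/C[C@@H]1C[C@]2(CC=C(C)C)C(=O)[C@@](CC=C(C)C)(C(=O)C(C(=O)c3ccc(O)c(O)c3)=C2O)C1(C)C`: > 20 ug/mL
compound 3 `CC(C)=CCC/C(C)=C/C[C@]12C[C@@H](CC=C(C)C)C(C)(C)[C@](C/C=C(\C)CCC=C(C)C)(C(=O)CC1=O)C2=O`: > 20 ug/mL

In a functional assay on SGC-7901 cells (Homo sapiens) for inhibition (a higher number here means a weaker inhibitor, a lower number a stronger inhibitor), compound 1 gives 8.5 ug/mL. Compound 3 gives > 20 ug/mL, which is a limit of the assay and not a number. Compound 2 likewise gives > 20 ug/mL, a limit only. Going by the values given here, the one counted step in this assay, an at least 2.3-fold lower number from compound 3 to compound 1 (0.37 log units; beyond the scatter), goes with the change (hydrogen in place of 3-methylbut-2-en-1-yl on a saturated chain carbon bound to a double-bonded chain carbon); it is a lower bound on the real step, since the starting value is a limit.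

Compound 4 `CC(C)=CC[C@@H]1C[C@]2(CC=C(C)C)C(=O)[C@@](CC=C(C)C)(C(=O)C(C(=O)c3ccc(O)c(O)c3)=C2O)C1(C)C` has not been measured. It differs from compound 2 by hydrogen in place of 3-methylbut-2-en-1-yl on a saturated chain carbon bound to a double-bonded chain carbon, the same change at the same place as from compound 3 to compound 1. How the core of compound 2 differs from that of compound 3 is not broken down here.

For compound 4 a step of an at least 1.6-fold lower number from compound 2 to compound 4 (0.22 log units; that floor lies within the scatter) is expected, because an at least 2.3-fold lower number from compound 3 to compound 1 (0.37 log units; beyond the scatter) shows that this change lowered the number at least modestly once before. The estimate for compound 4 is 12 ug/mL, with a range from 5 ug/mL to 30 ug/mL. As far as these compounds go, the range is wide, and a further limit remains quite possible, because the limit of > 20 ug/mL in this assay, at which 2 of the 3 values shown sit, is where the parent value of compound 2 sits, so the true starting point of the step is unknown.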

Compound 4, half-maximal inhibitory concentration: 13.7 ug/mL
For compound 4 the middle estimate is 1.1-fold (0.06 log units) below the measured one, and the stated range covers the measured number.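

Working notes on carrying the side-chain change across cores: in this assay, hydrogen in place of 3-methylbut-2-en-1-yl on a saturated chain carbon bound to a double-bonded chain carbon, which shortens 3,7-dimethylocta-2,6-dien-1-yl to 3-methylbut-2-en-1-yl, goes with an at least 1.4-fold lower number from compound 2 to compound 4 (0.16 log units; that floor lies within the scatter). Compound 2 gives > 20 ug/mL, which is a limit of the assay and not a number. On both cores the shorter side chain goes with a measured number where the longer one gives only a limit, but this does not establish that the step keeps its size from one core to the other, and the floor on the core of compound 2 does not by itself clear the scatter: the same change on two cores in this assay, an at least 2.3-fold lower number (0.37 log units; beyond the scatter) from compound 3 to compound 1 and an at least 1.4-fold lower number (0.16 log units; that floor lies within the scatter) from compound 2 to compound 4; the limit leaves it open whether they differ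

The true size of both steps stays open, as does any ranking of the two compounds with the longer chain, compound 2 and compound 3: the limit of > 20 ug/mL in this assay, at which 2 of the 4 values shown sit. Also open is whether this result is specific to the unsaturated chain, since the compounds shown do not tell how a saturated alkyl chain, an amine or a carboxylic acid in place of the 3-methylbut-2-en-1-yl group would read in this assay.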